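A few compounds are considered here, and "the series" means these few. Any claim that something is new, unique, unknown or untested is made for them only; others in the source may bear on it.

The measured compounds, each with its structure and its result:

Compound 1, `COc1cc(NC(C)CCCNC(=O)Nc2ccc(Cl)c(C(F)(F)F)c2)c2ncccc2c1`. In a physicochemical assay for inhibition, read by spectrophotometry, tested at 100 uM (a lower number here means less inhibition, a higher number more inhibition at the concentration tested (going by the name of the read-out)), compound 1 gives 61%.

Compound 2, `COc1ccc(/C(=N/NC(=O)NCCCC(C)Nc2cc(OC)cc3cccnc23)c2ccccc2)cc1`. In this assay compound 2 gives 77%.

Of these two numbers, compound 1 stands lowest. Its nearest neighbour is compound 2, whose inhibition lies higher by a gap that is beyond the usual scatter of such measurements, so the two can be told apart. Within the data shown here, no pair of measured compounds differs in a single place, so there is no measured step to lean on.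

Compound 3, `COc1cc(NC(C)CCCNC(=O)NNC(=O)NCCCCCO)c2ncccc2c1`, has not yet been tested in this assay. It differs from compound 1 in one place: ((5-hydroxypentyl)carbamoyl)amino in place of 4-chloro-3-(trifluoromethyl)phenyl on an amide-type nitrogen. Among the measured compounds shown here, since no measured step resembles this change, its size rests on expectation alone. A downward step, beyond the scatter, is expected, a number 23 percentage points lower from compound 1 to compound 3 (beyond the scatter). Compound 3 is therefore expected to give about 38% in this assay, with a range from 12% to 62%, because compound 1 already starts from 61% and the step is expected to fall from there.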

Compound 3, a percentage reported as inhibition, at one concentration (the size of the read-out at that concentration, not a potency): 54%
Beside the measured number, compound 3's estimate is 16 percentage points below it; the range from low to high includes it.
By their numbers in this assay, from the lowest: compounds 3 and 1 (each within the scatter of the next); then compound 2.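

In this assay, putting ((5-hydroxypentyl)carbamoyl)amino in place of 4-chloro-3-(trifluoromethyl)phenyl on the amide-type nitrogen gives a number 7 percentage points lower from compound 1 to compound 3 (within the scatter) and so leaves the two compounds indistinguishable. Among these compounds, this is the first measured step at this position, and it shows that, in this one pair, the six-membered aromatic ring bearing chlorine and trifluoromethyl can give way to an open chain with no ring and with hydrogen-bond donors and acceptors without a change that can be told from scatter. No accompanying measurement bears on why the two compounds read alike.

What the compounds shown leave open is whether the hydroxyl at the end of the 5-hydroxypentyl chain contributes anything, since one pair cannot tell whether an amine, a carboxylic acid or a plain methyl at that end, or a shorter or longer chain, would read the same. On these data alone, it also stays open whether a simple unsubstituted phenyl on the same amide-type nitrogen would fall in line with compound 1 and compound 3 or would stand apart from them.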